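A few compounds are considered here, and "the series" means these few. Any claim that something is new, unique, unknown or untested is made for them only; others in the source may bear on it.

Measured compounds:
- compound 1 `COc1nc2ccc(Br)cc2cc1C(c1ccccc1)n1cc(-c2ccc(Br)cc2)nn1`: 6.28%
- compound 2 `CCCCCCCc1cn(C(c2ccccc2)c2cc3cc(Br)ccc3nc2OC)nn1`: 0.17%
- compound 3 `CCCCCCCCc1cn(C(c2ccccc2)c2cc3cc(Br)ccc3nc2OC)nn1`: 14.6%

These three share a core and differ only in the group on one aromatic carbon of the ring attached to the shared core. In an ADME assay on HEK293 cells (Homo sapiens) for cytotoxicity, read by sulforhodamine B assay, with a stated time of 48 h, tested at 10 uM (a lower number here means less inhibition, a higher number more inhibition at the concentration tested (going by the name of the read-out)), compound 3 gives the highest of the three numbers; its nearest neighbour is compound 1, separated by a number 8.3 percentage points higher from compound 1 to compound 3 (within the scatter), and its furthest is compound 2, separated by a number 14.4 percentage points higher from compound 2 to compound 3 (beyond the scatter).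

Compound 4 `CCCc1cn(C(c2ccccc2)c2cc3cc(Br)ccc3nc2OC)nn1` carries a shorter chain in the same place. The change from compound 3 is hydrogen in place of pentyl on a saturated chain carbon, three bonds along the chain from an aromatic carbon.

Among the measured compounds shown here, only one measured step alters the length of this chain: a number 14.4 percentage points higher from compound 2 to compound 3 (beyond the scatter), where a single added carbon went with a modest rise. The steps of a number 6.1 percentage points lower from compound 1 to compound 2 (within the scatter) and a number 8.3 percentage points higher from compound 1 to compound 3 (within the scatter) swap the chain for a ring and stay within the scatter, so they set no direction. For the measured compounds named here, removing five chain carbons is a larger cut than the one carbon added between compound 2 and compound 3, and the one relevant step points toward a lower number for shorter chains.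

Going by the values given here, the expected step is therefore a number 10.6 percentage points lower from compound 3 to compound 4 (beyond the scatter), downward, though with only one guiding step this expectation is loose. Compound 4 is estimated at 4%, within a range of -6% to 14%.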

Compound 4, a percentage reported as inhibition, at one concentration (the size of the read-out at that concentration, not a potency): 0.85%
Beside the measured number, compound 4's estimate is 3.2 percentage points above it; low and high end bracket the measured number.
By their numbers in this assay, from the lowest: compounds 2, 4, 1 and 3 (each within the scatter of the next, the first and the last beyond it).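

Shortening the octyl chain to propyl on this aromatic carbon gives, in this assay, a number 13.8 percentage points lower from compound 3 to compound 4 (beyond the scatter) and so matches the size of the modest change already seen for one added carbon between the heptyl and octyl chains. The number does not follow chain length steadily, however: the heptyl and propyl chains cannot be told apart, with a number 0.7 percentage points higher from compound 2 to compound 4 (within the scatter) and compound 2 going against any simple rule that a longer chain gives a higher number. Nor does a propyl chain separate from the 4-bromophenyl group, with a number 5.4 percentage points lower from compound 1 to compound 4 (within the scatter) and compound 1 also lying within the scatter of compound 3, so the octyl chain stands apart only from the heptyl and propyl chains.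

The compounds shown leave open whether a longer chain such as decyl would keep the higher number, or whether an amine or a carboxylic acid at the end of the chain would change the picture. Nothing at hand gives a reason for the separate place of the octyl chain.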